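A few compounds are considered here, and "the series" means these few. Any claim that something is new, unique, unknown or untested is made for them only; others in the source may bear on it.

Compound 1 `COc1cc2c(Oc3ccc(NC(=O)c4nn(-c5ccccc5C(F)(F)F)c(=O)cc4C)cc3F)ccnc2cc1OCCCN1CCN(C)CC1` gives 240 nM in a functional assay on NCI-H460 cells (Homo sapiens) for inhibition, read by MTT assay, with a stated time of 72 h; a higher number here means a weaker inhibitor, a lower number a stronger inhibitor.
Compound 2 `COc1cc2c(Oc3ccc(NC(=O)c4nn(-c5ccc(Cl)cc5)c(=O)cc4C)cc3F)ccnc2cc1OCCCN1CCC(C)CC1` gives 370 nM in this assay.

Only these two numbers exist, and compound 2 stands within the usual scatter of compound 1, so the two values show no separation that can be read as a difference. For the measured compounds named here, the two structures differ in more than one place, so no single step connects them.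

Compound 3 `COc1cc2c(Oc3ccc(NC(=O)c4nn(-c5ccc(Cl)cc5)c(=O)cc4C)cc3F)ccnc2cc1OCCCN1CCN(C)CC1` is not yet measured. It is built from compound 2 by one change: 4-methylpiperazin-1-yl in place of 4-methylpiperidin-1-yl on a saturated chain carbon, three bonds along the chain from an oxygen on an aromatic ring. The resulting chain end is the same one that compound 1 carries, but compound 1 also differs from compound 2 elsewhere, so its value cannot be taken as a direct reading of this change.

Going by the values given here, with no measured step of this kind to lean on, the step from compound 2 to compound 3 is expected to stay within the scatter, with a 1.2-fold lower number from compound 2 to compound 3 (0.09 log units; within the scatter) pointing, if anywhere, to a slightly lower number. Compound 3 is therefore expected to give about 300 nM in this assay, most likely between 120 nM and 750 nM.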

Compound 3, half-maximal inhibitory concentration: 440 nM
Beside the measured number, compound 3's estimate is 1.5-fold (0.17 log units) below it; measured number inside the range.
By their numbers in this assay, from the lowest: compounds 1, 2 and 3 (each within the scatter of the next).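

In this assay, the change from 4-methylpiperidin-1-yl to 4-methylpiperazin-1-yl on a saturated chain carbon, three bonds along the chain from an oxygen on an aromatic ring, now has a direct reading: a 1.2-fold higher number from compound 2 to compound 3 (0.08 log units; within the scatter). Swapping a ring with 1 hetero atom for one with 2 at this chain end therefore leaves no difference that can be read in this assay, at least with the 4-chlorophenyl group in place. For the compounds shown here, compound 3 also gives the first single-change reading on the aromatic nitrogen, where 4-chlorophenyl in place of 2-(trifluoromethyl)phenyl gives a 1.8-fold higher number from compound 1 to compound 3 (0.26 log units; within the scatter), so neither change separates these compounds, and no supporting data on the result are available.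

The compounds shown leave open whether a chain end carrying a morpholine ring or a dimethylamino group, or a shorter chain such as 2-(4-methylpiperazin-1-yl)ethyl, would move the number beyond the scatter. They also leave open whether an unsubstituted phenyl ring or a 4-fluorophenyl group on the aromatic nitrogen would do so.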